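The source may report more compounds than this note shows. Statements on the series, on what has been measured and on what is new or still open speak of the compounds shown alone.

In a functional assay (strain AB) with Danio rerio as the target, read by microscopy, with a stated time of 1 h (a higher number here means that more compound is needed for the effect, a lower number that less compound is needed), compound 1 (`CCN1CCc2c(sc(NC(=O)Nc3ccc(Cl)cc3)c2C(N)=O)C1`) gives 3120 nM and compound 2 (`CN1CCc2c(sc(NC(=O)Nc3ccc(Cl)cc3)c2C(N)=O)C1`) gives 4700 nM so the two values stand within the scatter of each other. Compound 3 (`NC(=O)c1c(NC(=O)Nc2ccc(Cl)cc2)sc2c1CCN(CC1CCCCC1)C2`) has not yet been measured. It differs from compound 2 by cyclohexyl in place of hydrogen on a saturated chain carbon bound to an amine nitrogen in a ring, a difference that also reads methyl to cyclohexylmethyl. Among the measured compounds shown here, the one measured step at this place is a 1.5-fold higher number from compound 1 to compound 2 (0.18 log units; within the scatter) and it stays within the scatter, so it offers no direction, and no step beyond the scatter is expected in this assay for cyclohexyl. For the measured compounds named here, no measured compound carries a group of this size, which leaves the expectation wide. The expected step is a 1.6-fold lower number from compound 2 to compound 3 (0.19 log units; within the scatter) by this estimate. For compound 3 the estimated value is 3000 nM with 800 nM to 11000 nM as the expected range.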

Compound 3, half-maximal effective concentration: 1890 nM
Estimate against measurement, compound 3: 1.6-fold (0.20 log units) above, and the stated range covers the measured number.
By their numbers in this assay, from the lowest: compounds 3, 1 and 2 (each within the scatter of the next, the first and the last beyond it).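

Among the compounds shown here, at this place, on a saturated chain carbon bound to an amine nitrogen in a ring, the earlier pair showed no step beyond the scatter, whereas cyclohexyl in place of hydrogen gives the first such step in this assay with a 2.5-fold lower number from compound 2 to compound 3 (0.40 log units; beyond the scatter) in a modest size. Set against the methyl of compound 1, however, cyclohexyl stays within the scatter, at a 1.7-fold lower number from compound 1 to compound 3 (0.22 log units; within the scatter), so the change separates compound 3 only from compound 2 and the three compounds form no clear trend. Nothing available gives a reason for this step.

The compounds shown leave open whether the ring of carbon itself matters, or whether a longer chain such as hexyl would read the same at this place. They also leave open how a phenyl ring or a carboxylic acid carried on the same chain carbon would read in this assay.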